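This account rests on a few compounds, and the source may have more. Where it says the series, first, only, none or still open, it means among the compounds named here.

Working notes on the series. All compounds share the core of compound 1 `N=C(NCCCc1c[nH]cn1)NCCC(c1ccccc1)c1ccccn1` and were measured in a functional assay on ileum for antagonist activity at histamine H1 receptor (Cavia porcellus); a higher number here means weaker binding, a lower number tighter binding. Compound 1 gives 97.7 nM. Compound 2 `N=C(NCCCc1c[nH]cn1)NCCC(c1ccc(Cl)c(Cl)c1)c1ccccn1` gives 79.4 nM. Compound 3 `N=C(NCCCc1c[nH]cn1)NCCC(c1ccccc1)c1ccc(F)cc1` gives 34.7 nM, the lowest of the three numbers; the step of a 2.8-fold lower number from compound 1 to compound 3 (0.45 log units; beyond the scatter) and the gap to compound 2 both lie beyond the scatter. Compound 4 `N=C(NCCCc1c[nH]cn1)NCCC(c1ccccc1)c1ccc(Cl)c(Cl)c1` is not yet measured; it differs from compound 3 by 3,4-dichlorophenyl in place of 4-fluorophenyl on a saturated chain carbon bound to an aromatic carbon and a saturated chain carbon. Going by the values given here, the one measured step of the same kind is a 1.2-fold lower number from compound 1 to compound 2 (0.09 log units; within the scatter), although there the leaving group was phenyl rather than 4-fluorophenyl. On that basis no step beyond the scatter is expected in this assay, a 1.2-fold lower number from compound 3 to compound 4 (0.06 log units; within the scatter). Compound 4 is therefore estimated at 30 nM, within 12 nM to 80 nM.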

Compound 4, dissociation constant: 195 nM
Estimate against measurement, compound 4: 6.5-fold (0.81 log units) below, and the stated range ends below it.
By their numbers in this assay, from the lowest: compound 3; then compounds 2, 1 and 4 (each within the scatter of the next, the first and the last beyond it).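

In this assay the step to 3,4-dichlorophenyl depends on the other group on the saturated chain carbon: a 5.6-fold higher number from compound 3 to compound 4 (0.75 log units; beyond the scatter) contrasts with a 1.2-fold lower number from compound 1 to compound 2 (0.09 log units; within the scatter) where pyridin-2-yl is retained. Replacing pyridin-2-yl has no single direction either, as a 2.5-fold higher number from compound 2 to compound 4 (0.39 log units; beyond the scatter) stands against a 2.8-fold lower number from compound 1 to compound 3 (0.45 log units; beyond the scatter) and a 2.0-fold higher number from compound 1 to compound 4 (0.30 log units; within the scatter) adds no clear shift. No measurement at hand accounts for this. Open, as far as these compounds go, is whether 4-chlorophenyl follows 4-fluorophenyl or 3,4-dichlorophenyl at this position. Also open, from the compounds shown here alone, is how 4-methoxyphenyl would fare with phenyl as the other group.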